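The source may report more compounds than this note shows. Statements on the series, on what has been measured and on what is new or still open speak of the compounds shown alone.

Compound 1 `Cc1ccccc1S(=O)(=O)NC(=O)C(C)(Cc1ccc(Cl)cc1)Oc1ccc(C(C)C)cc1`: > 10 mg/kg
Compound 2 `CC(C)c1ccc(OC(C)(Cc2ccc(Cl)cc2)c2nnn[nH]2)cc1`: 10 mg/kg

Among the compounds with values here, in a functional assay on the whole organism for inhibition, with Rattus norvegicus as the target (on this read-out higher numbers stand for an effect only at larger amounts of compound and lower numbers for an effect already at smaller amounts), compound 2 gives 10 mg/kg, the only actual number so far. Compound 1 gives > 10 mg/kg, which is a limit of the assay and not a number.

Compound 3 `CC(C)c1ccc(OC(C)(Cc2ccc(Cl)cc2)C(=O)CO)cc1` is still to be measured. The change from compound 2 is (hydroxymethyl)carbonyl in place of 1H-tetrazol-5-yl on a saturated chain carbon bound to an oxygen on an aromatic ring and two saturated chain carbons. Within the data shown here, no measured step covers this exchange, so the expectation rests on 10 mg/kg of compound 2 alone. In this assay a small move towards larger doses is expected, possibly none beyond the scatter. The expected size is a 1.2-fold higher number from compound 2 to compound 3 (0.08 log units; within the scatter). For compound 3 the estimated value is 12 mg/kg, with an expected range of 4 mg/kg to 35 mg/kg.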

Compound 3, dose for half-maximal effect: > 10 mg/kg
Compound 3 gave a limit, no number; the forecaster's own chance of this, stated with the estimate: 45%; the middle value lies beyond the limit too.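

In this assay, (hydroxymethyl)carbonyl in place of 1H-tetrazol-5-yl on a saturated chain carbon bound to an oxygen on an aromatic ring and two saturated chain carbons gives a number no lower from compound 2 to compound 3 (the limit leaves the size open). Within the data shown here, this exchange therefore brings no move towards smaller doses, and compound 2 still holds the only actual number. The step between compound 1 and compound 3 cannot be read, and the series offers little resolution at this position, as most of its values are limits: the limit of > 10 mg/kg in this assay, at which 2 of the 3 values shown sit.

Going by these compounds, how far compound 3 lies from compound 2 remains open, as does whether any group at this position can reach smaller doses than the 1H-tetrazol-5-yl of compound 2. A carboxylic acid or an amine on the same carbon could show whether an actual number is obtained in this assay.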